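This account rests on a few compounds, and the source may have more. Where it says the series, first, only, none or still open, it means among the compounds named here.

Measured compounds in a physicochemical assay for solubility, read by nephelometry, measured as kinetic solubility, at pH 2; on this read-out higher numbers stand for higher solubility and lower numbers for lower solubility:
Compound 1 `COc1ccc(-c2cc(-c3ccc(S(N)(=O)=O)cc3)cnc2N)cn1` gives > 100 ug/mL, which is a limit of the assay and not a number.
Compound 2 `COc1ccc(-c2cc(-c3ccc(S(=O)(=O)NC4CC4)cc3)cnc2N)cn1` gives > 100 ug/mL, again a limit of the assay.
Compound 3 `COc1ccc(-c2cc(-c3ccc(C(F)(F)F)cc3)cnc2N)cn1` gives > 100 ug/mL, also a limit of the assay.

Compound 3 therefore stands where every measured member of the series stands: all three values sit at the limit of > 100 ug/mL in this assay, at which 3 of the 3 values shown sit, and no number within the measurable range is known for any of them. Compound 4 `CNC(=O)c1ccc(-c2cnc(N)c(-c3ccc(OC)nc3)c2)cc1` is reached from compound 3 by methylcarbamoyl in place of trifluoromethyl on an aromatic carbon, placed para to a large group.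

Going by the values given here, three measured steps touch the same aromatic carbon or the group on it: a step that the two limits leave unreadable from compound 1 to compound 2, a step that the two limits leave unreadable from compound 1 to compound 3 and a step that the two limits leave unreadable from compound 2 to compound 3. None of them can be read in size, because both ends of each step sit at the limit of > 100 ug/mL in this assay, at which 3 of the 3 values shown sit. They tell only that sulfamoyl, cyclopropylsulfamoyl and trifluoromethyl at this position all leave the value at the limit; the direction and size of an exchange for methylcarbamoyl is not covered by any measured pair.

The expectation for compound 4 in this assay is accordingly a step of no readable size, a step that the limit leaves unreadable from compound 3 to compound 4, with the value most likely reported again as a limit. Compound 4 is estimated at 150 ug/mL, in the range 50 ug/mL to 450 ug/mL.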

Compound 4, solubility: 50 ug/mL
The estimate for compound 4 lay 3.0-fold (0.48 log units) above the measured number; the measured number falls inside the stated range.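

In this assay, methylcarbamoyl is the first group at this aromatic carbon, placed para to a large group, to give a number and not a limit of the assay, so this position is not shown to sit at the limit whatever the group. Methylcarbamoyl in place of trifluoromethyl is an at least 2.0-fold lower number from compound 3 to compound 4 (0.30 log units; that floor lies within the scatter), in place of cyclopropylsulfamoyl it is an at least 2.0-fold lower number from compound 2 to compound 4 (0.30 log units; that floor lies within the scatter), and in place of sulfamoyl it is an at least 2.0-fold lower number from compound 1 to compound 4 (0.30 log units; that floor lies within the scatter). These are floors only, and the steps among compound 1, compound 2 and compound 3 cannot be read, because those three compounds carry limits and not numbers: the limit of > 100 ug/mL in this assay, at which 3 of the 4 values shown sit.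

Whether the amide hydrogen or the carbonyl matters here stays open, since the compounds shown hold no dimethylcarbamoyl, no carboxylic acid and no amine at this carbon. Going by these compounds, the true size of the gap between methylcarbamoyl and the other three groups also stays open, as does whether that gap lies beyond the scatter of this assay.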